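The compounds below may be only part of what the source reports. "The series", "measured", "known", "first", "only" and "open" are said of these compounds alone.

In a functional assay on HeLa cells (Homo sapiens) for antiproliferative activity, read by MTT assay, with a stated time of 48 h (on this read-out lower numbers stand for stronger inhibition and higher numbers for weaker inhibition), compound 1 `Fc1ccccc1N1CCN(Cn2nc(-c3ccc4c(c3)OCCO4)oc2=S)CC1` gives 37300 nM. Compound 2 `S=c1oc(-c2ccc3c(c2)OCCO3)nn1CN1CCN(C(c2ccccc2)c2ccccc2)CC1` returns only a limit of the assay, > 50000 nM. Compound 3 `COc1ccc(N2CCN(Cn3nc(-c4ccc5c(c4)OCCO5)oc3=S)CC2)cc1` likewise returns only a limit, > 50000 nM, so no number stands for it. The new compound 4 `COc1ccccc1N1CCN(Cn2nc(-c3ccc4c(c3)OCCO4)oc2=S)CC1` differs from compound 3 as follows: 2-methoxyphenyl in place of 4-methoxyphenyl on an amine nitrogen in a ring. Within the data shown here, the one measured step touching the same ring nitrogen, an at least 1.3-fold higher number from compound 1 to compound 3 (0.12 log units; that floor lies within the scatter), stays within the scatter, and the limit of > 50000 nM in this assay, at which 2 of the 3 values shown sit, leaves its size open. Nothing in these numbers therefore points to a move beyond the scatter from compound 3 to compound 4, and compound 4 is expected to remain near the same limit. Compound 4 is expected to give 45000 nM, between 20000 nM and 100000 nM. This estimate means a step of an at least 1.1-fold lower number from compound 3 to compound 4 (0.04 log units; that floor lies within the scatter).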

Compound 4, half-maximal inhibitory concentration: > 50000 nM
Compound 4: no number, only a limit; the forecaster's own chance of this, stated with the estimate: 60%; at least 1.1-fold (0.04 log units) between middle value and limit.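

In this assay, the 2-methoxyphenyl of compound 4 gives a limit, as the 4-methoxyphenyl of compound 3 does, so the step between them cannot be read and neither compound carries a number. Methoxy in place of fluoro on an aromatic carbon gives an at least 1.3-fold higher number from compound 1 to compound 4 (0.12 log units; that floor lies within the scatter). Compound 1 alone has a measured number, and the true size of these steps stays open: the limit of > 50000 nM in this assay, at which 3 of the 4 values shown sit.

The compounds shown leave open whether a chloro, a hydroxyl or an amine on this phenyl would give a number clear of the limit.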